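Swapping chloro for methyl on compound 3's aryl ring

This account rests on a few compounds, and the source may have more. Where it says the series, first, only, none or still open, it means among the compounds named here.

Of the compounds shown here, three share a core and have been tested in a functional assay on NCI-H460 cells (Homo sapiens) for antiproliferative activity; a lower number here means a stronger inhibitor of growth, a higher number a weaker inhibitor of growth. Compound 1 `Cc1cnc2nc(-c3ccc4ccccc4c3)cc(O)c2c1` gives 398 nM. Compound 2 `Cc1cccc(-c2cc(O)c3cc(C)cnc3n2)c1` gives 389 nM. Compound 3 `Cc1ccc2c(O)cc(-c3cccc(Cl)c3)nc2n1` gives 41.7 nM, the lowest of the three numbers, and its distance from both other compounds lies beyond the scatter. From the compounds shown here alone, the next compound, compound 4 `Cc1cccc(-c2cc(O)c3ccc(C)nc3n2)c1`, is still untested in this assay. It differs from compound 3 by a single change: methyl in place of chloro on an aromatic carbon. Compound 2 also carries a methyl on that ring, though its core differs, and it gives 389 nM in this assay. The step of a 2.6-fold higher number from compound 3 to compound 4 (0.42 log units; beyond the scatter) is therefore expected to weaken growth inhibition modestly. Compound 4 is estimated at 110 nM, within a range from 40 nM to 320 nM.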

Compound 4, concentration for 50% growth inhibition: 17.8 nM
Compound 4: middle estimate off by 6.2-fold (0.79 log units), on the high side; the whole stated range lies above it.
By their numbers in this assay, from the lowest: compound 4; then compound 3; then compounds 2 and 1 (each within the scatter of the next).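

Seen in this assay the swap of chloro for methyl, on an aromatic carbon meta to a large group, gives a 2.3-fold lower number from compound 3 to compound 4 (0.37 log units; beyond the scatter) and so moves toward stronger growth inhibition. This position therefore accepts either group, and of these two, methyl gives the lower number. From the compounds shown here alone, whether a methoxy group, a fluoro group or an amine at this carbon would go lower still remains open, as does the outcome of the same swap on the core of compound 1. Nothing available here explains why methyl gives the lower number.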